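The source may hold more compounds than are shown below. What is called first, only, known or untested is meant among the compounds shown, and "the series" means these compounds.

Measured compounds:
compound 1, `COc1ccc(-c2cc(/C=C/C(=O)c3ccc(N)cc3)[nH]n2)cc1`, 103%
compound 2, `COc1cc(-c2cc(/C=C/C(=O)c3ccc(F)c(F)c3)[nH]n2)cc(OC)c1OC`, 90%

In a functional assay on MDA-MB-435 cells (Homo sapiens) for cytotoxicity, read by sulforhodamine B assay, with a stated time of 48 h, tested at 0.1 uM (a lower number here means a stronger effect, a higher number a weaker effect of the compound at the concentration tested), compound 1 stands highest of the two numbers; compound 2 gives 90%, lower by more than the usual scatter. For the measured compounds named here, the two differ in more than one place, so no single step connects them. Compound 3, `COc1ccc(-c2cc(/C=C/C(=O)c3ccc(N)cc3)[nH]n2)cc1OC`, differs from compound 1 by methoxy in place of hydrogen on an aromatic carbon. Going by the values given here, no measured step of this kind exists here, so the change is expected to give no step beyond the scatter in this assay. The expected step is a number 5 percentage points lower from compound 1 to compound 3 (within the scatter). Compound 3 is therefore estimated at 98%, within 80% to 110%.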

Compound 3, a percentage reported as activity, at one concentration (the size of the read-out at that concentration, not a potency): 98%
For compound 3 middle estimate and measured number coincide at the digits printed, within the range that was stated.
By their numbers in this assay, from the lowest: compounds 2, 3 and 1 (each within the scatter of the next, the first and the last beyond it).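

On the core of compound 1, methoxy in place of hydrogen on an aromatic carbon, ortho to a methoxy group and meta to a large group, gives in this assay a number 5 percentage points lower from compound 1 to compound 3 (within the scatter). This is the only single-place step among these compounds, and it shows that this position takes the added methoxy without a step beyond the scatter at the one concentration tested. Nothing available bears on the reason for this result. Going by these compounds, whether a hydroxy group, a fluorine atom or an amine on the same carbon would give a similar number stays open.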